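A few compounds are considered here, and "the series" means these few. Any claim that something is new, unique, unknown or untested is made for them only; others in the source may bear on it.

Compound 1 `COC(=O)C1=C(C)NC(=O)NC1c1ccoc1` gives 8% in an assay on membranes from CHO cells for displacement of a labelled ligand from adenosine receptor A1 (Homo sapiens), read by scintillation counting, with a stated time of 60 min, tested at 1 uM; on this read-out lower numbers stand for less inhibition and higher numbers for more inhibition at the one concentration tested (going by the name of the read-out). Compound 2 `COC(=O)C1=C(C)NC(=O)NC1c1cccs1` gives 6% in this assay, and compound 3 `CCNC(=O)C1=C(C)NC(=O)NC1c1ccoc1` gives 1% in this assay. The step of a number 2 percentage points lower from compound 1 to compound 2 (within the scatter) goes with thiophen-2-yl in place of furan-3-yl on a saturated ring carbon. The step of a number 7 percentage points lower from compound 1 to compound 3 (within the scatter) goes with ethylamino in place of methoxy on a carbonyl carbon, which is also how the core of compound 3 differs from the core of compound 1. Compound 4 `CCNC(=O)C1=C(C)NC(=O)NC1c1cccs1` has not yet been measured; it carries thiophen-2-yl in place of furan-3-yl on a saturated ring carbon. Among the compounds with values here, this is the same kind of change as the one from compound 1 to compound 2, but the place differs: in compound 1 the saturated ring carbon is next to the ring atom that bears a methoxycarbonyl group (4 heavy atoms), in compound 3 next to the ring atom that bears an ethylcarbamoyl group (5 heavy atoms). Because the earlier step of a number 2 percentage points lower from compound 1 to compound 2 (within the scatter) stayed within the scatter, compound 4 is expected to show a step of a number 1 percentage points higher from compound 3 to compound 4 (within the scatter) of similar size. Compound 4 is therefore estimated at 2%, expected to fall between 0% and 10%.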

Compound 4, a percentage reported as inhibition, at one concentration (the size of the read-out at that concentration, not a potency): 1%
For compound 4 the middle estimate is 1 percentage points above the measured one; low and high end bracket the measured number.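

Setting thiophen-2-yl in place of furan-3-yl on the core of compound 3 gives no change at the digits printed from compound 3 to compound 4 (within the scatter) in this assay, and this matches the step on the core of compound 1: the same change on two cores in this assay, a number 2 percentage points lower (within the scatter) from compound 1 to compound 2 and no change at the digits printed (within the scatter) from compound 3 to compound 4, 2 percentage points apart, within the scatter of two such steps. Setting ethylamino in place of methoxy on a carbonyl carbon gives a number 5 percentage points lower from compound 2 to compound 4 (within the scatter), which also matches its earlier step: the same change on two cores in this assay, a number 7 percentage points lower (within the scatter) from compound 1 to compound 3 and a number 5 percentage points lower (within the scatter) from compound 2 to compound 4, 2 percentage points apart, within the scatter of two such steps. Both changes thus carry from one core to the other in this series, but only as steps within the scatter, so this does not show that either would carry over in the same way on a compound giving a clear inhibition.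

The compounds shown leave open whether a phenyl group on the saturated ring carbon, or a longer chain such as butylamino on the carbonyl carbon, would give a step beyond the scatter. They also give no potency, as each compound is read at one concentration only.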